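Swapping a side chain at the assay limit

The source may hold more compounds than are shown below. What is called first, only, known or untested is meant among the compounds shown, and "the series" means these compounds.

Of the compounds shown here, two have so far been read in an ADME assay on a cell-free system (plasma, Rattus norvegicus, strain Sprague-Dawley) for metabolic stability, read by LC-MS, with a stated time of 4 h; on this read-out lower numbers stand for a less stable compound and higher numbers for a more stable compound. Compound 1 `CC(Oc1nn(-c2ccccc2F)c2ccc(F)cc12)C(=O)N1CCOCC1` gives > 80%, which is a limit of the assay and not a number. Compound 2 `O=C1NCCN1CCOc1nn(-c2ccccc2F)c2ccc(F)cc12` gives > 80%, which is likewise a limit. Compound 2 therefore stands at the limit of > 80% in this assay, at which 2 of the 2 values shown sit.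

Compound 3 `O=C(COc1nn(-c2ccccc2F)c2ccc(F)cc12)N1CCOCC1` differs from compound 2 in one place: (morpholin-4-yl)carbonyl in place of (2-oxoimidazolidin-1-yl)methyl on a saturated chain carbon bound to an oxygen on an aromatic ring. Going by the values given here, no measured step shows what this change does. Compound 1 also carries (morpholin-4-yl)carbonyl, and its reading of > 80% is a limit, so no step beyond the scatter is expected in this assay. The estimated step is a step that the limit leaves unreadable from compound 2 to compound 3. For compound 3 the expected value is 90%, with an estimated range from 78% to 100%.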

Compound 3, percent of the compound remaining: 1%
Beside the measured number, compound 3's estimate is 89 percentage points above it; measured number below the stated range.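

In this assay, (morpholin-4-yl)carbonyl in place of (2-oxoimidazolidin-1-yl)methyl on a saturated chain carbon bound to an oxygen on an aromatic ring gives a number at least 79 percentage points lower from compound 2 to compound 3 (beyond the scatter), so this position is not indifferent to the side chain. The (morpholin-4-yl)carbonyl group alone does not set the reading, as compound 1 carries it too: hydrogen in place of methyl on a saturated chain carbon bound to a carbonyl carbon and an oxygen on an aromatic ring gives a number at least 79 percentage points lower from compound 1 to compound 3 (beyond the scatter), a single small change with a large step. Going by these compounds alone, compound 3 is the one compound off the top of the read-out: the limit of > 80% in this assay, at which 2 of the 3 values shown sit.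

Going by these compounds, what an ethyl group on that chain carbon would give remains open. So does the reading of a piperidine amide or a carboxylic acid in place of the (morpholin-4-yl)carbonyl of compound 3.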